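The compounds below may be only part of what the source reports. "The series", "measured", "known", "first", "only" and "open" are said of these compounds alone.

Compound 1 `COc1ccccc1-c1nnc(-c2ccc(C(=O)N/N=C/c3cc(O)ccc3O)cc2)o1` is the reference point of this small set. In an ADME assay on THP-1 cells (Homo sapiens) for cytotoxicity (a lower number here means a stronger inhibitor, a higher number a weaker inhibitor), compound 1 gives 100000 nM, the smallest of the three numbers recorded, although the gap to compound 3 lies within the scatter. Compound 2 `COc1ccccc1-c1nnc(-c2ccc(C(=O)N/N=C/c3ccc([N+](=O)[O-])cc3)cc2)o1` gives 203000 nM in this assay, and compound 3 `COc1ccccc1-c1nnc(-c2ccc(C(=O)N/N=C/c3cccc([N+](=O)[O-])c3)cc2)o1` gives 119000 nM. The step of a 2.0-fold higher number from compound 1 to compound 2 (0.31 log units; beyond the scatter) is the only one in the set that clears the scatter; the step of a 1.2-fold higher number from compound 1 to compound 3 (0.08 log units; within the scatter) does not, and the step of a 1.7-fold lower number from compound 2 to compound 3 (0.23 log units; within the scatter) does not either.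

Compound 4 `COc1ccccc1-c1nnc(-c2ccc(C(=O)N/N=C/c3ccccc3[N+](=O)[O-])cc2)o1` is not yet measured. Relative to compound 1 the change is 2-nitrophenyl in place of 2,5-dihydroxyphenyl on a carbon with a double bond to nitrogen. The two measured steps that bear on it are the swaps of the same dihydroxyphenyl for a nitrophenyl in compound 2 and compound 3: one gave a modest rise in the number, the other stayed within the scatter. A nitrophenyl in the third position on that carbon is therefore expected to land in the same region, a small rise or none beyond the scatter, and the expected step is a 1.4-fold higher number from compound 1 to compound 4 (0.15 log units; within the scatter). Compound 4 is accordingly estimated at 140000 nM in this assay, with a range from 80000 nM to 250000 nM.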

Compound 4, half-maximal inhibitory concentration: 161000 nM
The estimate for compound 4 lay 1.2-fold (0.06 log units) below the measured number; the measured number falls inside the stated range.
By their numbers in this assay, from the lowest: compounds 1, 3, 4 and 2 (each within the scatter of the next, the first and the last beyond it).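

With the 2-nitrophenyl group now in place on the carbon with a double bond to nitrogen, the nitrophenyl compounds can be compared further in this assay: the step of a 1.4-fold higher number from compound 3 to compound 4 (0.13 log units; within the scatter) and the step of a 1.3-fold lower number from compound 2 to compound 4 (0.10 log units; within the scatter) both leave compound 4 unresolved from the other two nitrophenyl compounds. The step of a 1.6-fold higher number from compound 1 to compound 4 (0.21 log units; within the scatter) also leaves compound 4 unresolved from compound 1, so replacing 2,5-dihydroxyphenyl, with its 2 hydrogen-bond donors, by a nitrophenyl group with 0 does not consistently give a step beyond the scatter: compound 2 clears it, whereas compound 3 and compound 4 do not. No measurement at hand bears on why the numbers fall as they do.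

The compounds shown leave open whether a group of a different kind on this carbon, such as an amine-bearing phenyl, a carboxylic acid-bearing phenyl or a cyclohexyl ring, would separate from compound 1 by more than the scatter. As far as these compounds go, it also remains open whether a phenyl carrying a single hydroxyl group would stay unresolved from the 2,5-dihydroxyphenyl group.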